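A few compounds are considered here, and "the series" means these few. Any claim that something is new, unique, unknown or untested is made for them only; others in the source may bear on it.

Compound 1 `O=C(Nc1ccc(Oc2ccnc3[nH]ccc23)cc1)c1cc(-c2ccc(F)cc2)ncn1`: 13000 nM
Compound 2 `O=C(Nc1ccc(Oc2ccnc3[nH]ccc23)cc1)c1cc(-c2ccc(Br)cc2)ncn1`: 9870 nM

Both were tested in a functional assay on A549 cells (Homo sapiens) for cytotoxicity, read by MTT assay, with a stated time of 72 h; on this read-out higher numbers stand for weaker inhibition and lower numbers for stronger inhibition. Compound 2 and compound 1 lie within the scatter of each other, since the step of a 1.3-fold lower number from compound 1 to compound 2 (0.12 log units; within the scatter) is small. Compound 3 `Cc1ccc(-c2cc(C(=O)Nc3ccc(Oc4ccnc5[nH]ccc45)cc3)ncn2)cc1` is not yet measured; it differs from compound 2 by methyl in place of bromo on an aromatic carbon. Within the data shown here, the one measured step, a 1.3-fold lower number from compound 1 to compound 2 (0.12 log units; within the scatter), also exchanged a group on that same aromatic carbon and stayed within the scatter. The expected step is therefore a 1.0-fold higher number from compound 2 to compound 3 (0.01 log units; within the scatter), none beyond the scatter. Compound 3 is estimated at 10000 nM in this assay, with a range from 4500 nM to 22000 nM.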

Compound 3, half-maximal inhibitory concentration: 5410 nM
Compound 3: middle estimate off by 1.8-fold (0.27 log units), on the high side; the range from low to high includes it.
By their numbers in this assay, from the lowest: compounds 3, 2 and 1 (each within the scatter of the next, the first and the last beyond it).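

In this assay, among these compounds, the step of a 2.4-fold lower number from compound 1 to compound 3 (0.38 log units; beyond the scatter) is the first at this position to pass the usual scatter, though only modestly. Bromo and methyl do not separate, with a 1.8-fold lower number from compound 2 to compound 3 (0.26 log units; within the scatter) for that exchange, so on this 4-substituted phenyl ring only fluoro and methyl stand apart. No available evidence accounts for this difference.

Going by these compounds, it remains open whether an amine, a carboxylic acid or a longer chain such as propyl at this carbon would move the number further, and in which direction.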